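Trimethoxyphenyl in Place of 4-Methylphenyl at the Carbonyl

The source may report more compounds than this note shows. Statements on the series, on what has been measured and on what is new or still open speak of the compounds shown alone.

Compound 1, `COc1cc(-c2nnc3n2NC(c2cccs2)C(C(=O)c2ccc(F)cc2)S3)cc(OC)c1OC`, gives 43700 nM in a functional assay on MCF7 cells (Homo sapiens) for cytotoxicity, read by MTT assay, with a stated time of 48 h; on this read-out lower numbers stand for stronger inhibition and higher numbers for weaker inhibition.
Compound 2, `COc1cc(-c2nnc3n2NC(c2ccco2)C(C(=O)c2ccc(C)cc2)S3)cc(OC)c1OC`, gives > 100000 nM in this assay, and that value is a limit of the assay rather than a number.

On the numbers shown, compound 2 stands at the limit of > 100000 nM in this assay, at which 1 of the 2 values shown sits, so nothing more than that limit is known of its potency. Compound 3, `COc1cc(C(=O)C2Sc3nnc(-c4cc(OC)c(OC)c(OC)c4)n3NC2c2ccco2)cc(OC)c1OC`, has not yet been measured in this assay. It differs from compound 2 by 3,4,5-trimethoxyphenyl in place of 4-methylphenyl on a carbonyl carbon. Within the data shown here, no pair of measured compounds here differs in one place, so no measured step sets the size of such a change. The step from compound 2 to compound 3 is expected to be an at least 1.4-fold lower number from compound 2 to compound 3 (0.15 log units; that floor lies within the scatter), a modest shift in either direction that may not exceed the usual scatter. Compound 3 is therefore estimated at 70000 nM, with a range from 15000 nM to 250000 nM.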

Compound 3, half-maximal inhibitory concentration: > 100000 nM
Compound 3 ended at the assay's limit; the forecaster's own chance of this, stated with the estimate: 45%; middle value at least 1.4-fold (0.15 log units) from the limit.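

Compound 2 and compound 3 both end at a limit of this assay rather than at a number, so no step between them can be read: the limit of > 100000 nM in this assay, at which 2 of the 3 values shown sit.

The compounds shown leave open whether 3,4,5-trimethoxyphenyl in place of 4-methylphenyl on a carbonyl carbon changes potency at all.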